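Trimming a Long Carboxylic Acid Tail

This account rests on a few compounds, and the source may have more. Where it says the series, first, only, none or still open, it means among the compounds named here.

The three measured compounds share one core and differ only in the chain attached through an oxygen on the aromatic ring. In an assay (Cricetulus griseus) for inhibition of aldehyde dehydrogenase, mitochondrial (Homo sapiens) (a lower number here means a stronger inhibitor, a higher number a weaker inhibitor), compound 1, `O=c1c(-c2ccc(O)cc2)coc2cc(OCCOCCOCCO)ccc12`, gives 40 nM. Compound 3, `CCOC(=O)COc1ccc2c(=O)c(-c3ccc(O)cc3)coc2c1`, gives 130 nM, which is a step of a 3.3-fold higher number from compound 1 to compound 3 (0.51 log units; beyond the scatter). Compound 2, `O=C(O)CCCCCCCCCCCCCCCOc1ccc2c(=O)c(-c3ccc(O)cc3)coc2c1`, carries a much longer acid chain, and in this assay compound 2 gives only a limit, > 9000 nM, so it stands at the limit of > 9000 nM in this assay, at which 1 of the 3 values shown sits, without a number of its own. Compound 4, `O=C(O)CCCCCCCOc1ccc2c(=O)c(-c3ccc(O)cc3)coc2c1`, is compound 2 with that chain cut back: carboxy in place of 8-carboxyoctyl on a saturated chain carbon, seven bonds along the chain from an oxygen on an aromatic ring. For the measured compounds named here, no measured step changes a chain in this way, so the move is judged indirectly. The step of a 3.3-fold higher number from compound 1 to compound 3 (0.51 log units; beyond the scatter) shows that swapping the tail moves this assay only modestly, and both compound 1 and compound 3, with their short tails, return real numbers rather than limits. Compound 4 is expected to give 1200 nM, within 200 nM to 9000 nM. The expected step is an at least 7.5-fold lower number from compound 2 to compound 4 (0.87 log units; beyond the scatter).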

Compound 4, half-maximal inhibitory concentration: 40 nM
Estimate against measurement, compound 4: 30-fold (1.48 log units) above, outside the stated range (below it).
By their numbers in this assay, from the lowest: compounds 1 and 4 (each within the scatter of the next); then compound 3. At a limit, above all of these: compound 2.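

Cutting 8-carboxyoctyl back to carboxy at this place, seven bonds along the chain from an oxygen on an aromatic ring, gives an at least 220-fold lower number from compound 2 to compound 4 (2.35 log units; beyond the scatter) in this assay, so chain length matters far more here than the earlier tail swap suggested. The shorter chain still ends in a carboxylic acid, yet there is no change at the digits printed from compound 1 to compound 4 (within the scatter) and a 3.3-fold lower number from compound 3 to compound 4 (0.51 log units; beyond the scatter), so in this assay an acid at the chain end is compatible with the best numbers shown. The result for compound 2 remains a limit, not a number: the limit of > 9000 nM in this assay, at which 1 of the 4 values shown sits.

The compounds shown leave open at which chain length between compound 4 and compound 2 the number begins to climb. As far as these compounds go, whether an amide or an amine at the chain end would match the carboxylic acid also remains open.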